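Benzylamino in place of 4-methylpiperazin-1-yl

A few compounds are considered here, and "the series" means these few. Any claim that something is new, unique, unknown or untested is made for them only; others in the source may bear on it.

Among the compounds with values here, in a functional assay on MCF7 cells (Homo sapiens) for antiproliferative activity, read by MTT assay, with a stated time of 24 h (a higher number here means a weaker inhibitor, a lower number a stronger inhibitor), compound 1 `CCCCc1oc2ccccc2c1C(=O)c1cc(I)c(OCCCN2CCN(C)CC2)c(I)c1` gives 5370 nM, the lower of the two numbers measured so far. Compound 2 `CCCCc1oc2ccccc2c1C(=O)c1cc(I)c(OCCCN2CCN(Cc3ccccc3)CC2)c(I)c1`, with phenyl in place of hydrogen on a saturated chain carbon bound to an amine nitrogen in a ring, gives 28700 nM. Within the data shown here, the one measured step, a 5.3-fold higher number from compound 1 to compound 2 (0.73 log units; beyond the scatter), is modest in size.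

Compound 3 `CCCCc1oc2ccccc2c1C(=O)c1cc(I)c(OCCCNCc2ccccc2)c(I)c1` departs from compound 1 at a single place: benzylamino in place of 4-methylpiperazin-1-yl on a saturated chain carbon, three bonds along the chain from an oxygen on an aromatic ring. Benzylamino stands in place of 4-methylpiperazin-1-yl on a saturated chain carbon, three bonds along the chain from an oxygen on an aromatic ring.

The measured step bears on this change only in part. A six-membered aromatic ring of carbon only is present in both compound 2 and compound 3, but compound 3 also lacks the six-membered non-aromatic ring with 2 hetero atoms, a loss no measurement here covers. Going by compound 2 and its a 5.3-fold higher number from compound 1 to compound 2 (0.73 log units; beyond the scatter), a rise of similar or somewhat smaller size is expected in this assay. The estimated step is a 2.4-fold higher number from compound 1 to compound 3 (0.38 log units; beyond the scatter). For compound 3 the expected value is 13000 nM, with an estimated range of 4500 nM to 38000 nM.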

Compound 3, half-maximal inhibitory concentration: 8050 nM
The estimate for compound 3 lay 1.6-fold (0.21 log units) above the measured number; the range from low to high includes it.
By their numbers in this assay, from the lowest: compounds 1 and 3 (each within the scatter of the next); then compound 2.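

In this assay, benzylamino in place of 4-methylpiperazin-1-yl, on a saturated chain carbon three bonds along the chain from an oxygen on an aromatic ring, gives a step that cannot be told from the scatter (a 1.5-fold higher number from compound 1 to compound 3 (0.18 log units; within the scatter)), so at this position the assay does not separate the two groups. The earlier step (a 5.3-fold higher number from compound 1 to compound 2 (0.73 log units; beyond the scatter)) left open whether the six-membered aromatic ring of carbon only goes with a higher number wherever it stands, and compound 3 shows that it does not: compound 3 holds that ring and the six-membered non-aromatic ring with 2 hetero atoms is gone, yet its number stays within the scatter of compound 1, while compound 2, which holds both rings, goes against any reading of the aromatic ring alone as harmful or harmless. Nothing measured here accounts for these numbers.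

From the compounds shown here alone, whether a smaller amine such as dimethylamino, or a morpholine ring, would read the same at this position remains open. So does the effect of a methyl on the benzylamino nitrogen, or of a shorter or longer chain between the oxygen and the amine.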